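The source may hold more compounds than are shown below. What is called first, only, known or untested is meant among the compounds shown, and "the series" means these compounds.

Of the compounds shown here, three sharing one core have been tested in a functional assay on MGC-803 cells (Homo sapiens) for inhibition, read by sulforhodamine B assay; on this read-out lower numbers stand for stronger inhibition and higher numbers for weaker inhibition. Compound 1 `Cc1ccc(NC2=CC(=O)c3nc4n(c3C2=O)[C@H]2OC[C@@H](O)[C@H]2OC4)cc1C` gives 860 nM. Compound 2 `O=C1C=C(Nc2ccccc2)C(=O)c2c1nc1n2[C@H]2OC[C@@H](O)[C@H]2OC1` gives 1730 nM, which places it second highest of the three numbers. Compound 3 `CCOc1ccccc1NC1=CC(=O)c2nc3n(c2C1=O)[C@H]1OC[C@@H](O)[C@H]1OC3` gives 2450 nM. The steps among them are small: a 2.0-fold higher number from compound 1 to compound 2 (0.30 log units; within the scatter), a 1.4-fold higher number from compound 2 to compound 3 (0.15 log units; within the scatter), and only a 2.8-fold higher number from compound 1 to compound 3 (0.45 log units; beyond the scatter) reaches beyond the scatter. Each of these steps swaps one aromatic group for another on the amine nitrogen.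

Compound 4 `O=C1C=C(N2CCCCC2)C(=O)c2c1nc1n2[C@H]2OC[C@@H](O)[C@H]2OC1` has not yet been measured. It differs from compound 2 in one place: piperidin-1-yl in place of anilino on a double-bonded ring carbon. Among the measured compounds shown here, no measured step trades the aromatic ring on that nitrogen for a non-aromatic one, and none removes the hydrogen-bond donor there, so none bears directly on this change. What the measured steps do show is that variation at this position has so far moved the numbers in this assay only modestly. The expected step in this assay is a 2.0-fold higher number from compound 2 to compound 4 (0.31 log units; beyond the scatter), most likely towards a higher number, though the absence of a directly comparable step leaves a wide range open in either direction. Compound 4 is therefore expected to give 3500 nM in this assay, within a range from 900 nM to 14000 nM.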

Compound 4, half-maximal inhibitory concentration: > 8000 nM
Compound 4 ended at the assay's limit; the forecaster's own chance of this, stated with the estimate: 10%; at least 2.2-fold (0.35 log units) between middle value and limit.
By their numbers in this assay, from the lowest: compounds 1, 2 and 3 (each within the scatter of the next, the first and the last beyond it). At a limit, above all of these: compound 4.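

In this assay compound 4 gives > 8000 nM, which is a limit and not a number: the limit of > 8000 nM in this assay, at which 1 of the 4 values shown sits.

Replacing the ring on the nitrogen gives an at least 4.6-fold higher number from compound 2 to compound 4 (0.66 log units; beyond the scatter), and the comparison with the dimethyl-substituted compound gives an at least 9.3-fold higher number from compound 1 to compound 4 (0.96 log units; beyond the scatter), whereas the largest step among the earlier swaps of one aromatic group for another was a 2.8-fold higher number from compound 1 to compound 3 (0.45 log units; beyond the scatter). The position on the double-bonded ring carbon therefore matters more than those earlier swaps suggested: leaving the aromatic ring and the nitrogen's hydrogen-bond donor behind costs more inhibition than changing which aromatic group is attached.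

Both features change together in compound 4, so the compounds shown cannot tell whether the loss of the aromatic ring, the loss of the donor or both lie behind the step, and a cyclohexylamino group, with a non-aromatic ring on a nitrogen that keeps its hydrogen, would separate the two. As far as these compounds go, the full size of the step also stays open, as the limit marks only where the reading ends.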